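A few compounds are considered here, and "the series" means these few. Any claim that something is new, unique, unknown or untested is made for them only; others in the source may bear on it.

Measured so far in a physicochemical assay for solubility, at pH 7.4; on this read-out higher numbers stand for higher solubility and lower numbers for lower solubility:
- compound 1 `O=C(/C=C/c1ccc(/C=C/C(=O)c2ccccc2)cc1)NO`: 3000 nM
- compound 2 `CN1CCN(c2cccc(C(=O)/C=C/c3ccc(/C=C/C(=O)NO)cc3)c2)CC1`: 16000 nM

Compound 1 stands lowest of these two numbers, and compound 2 is its nearest neighbour. Compound 3 `CN1CCN(c2ccc(C(=O)/C=C/c3ccc(/C=C/C(=O)NO)cc3)cc2)CC1` has not yet been measured in this assay. It differs from compound 1 by one change, (4-methylpiperazin-1-yl in place of hydrogen on an aromatic carbon), which puts 4-methylpiperazin-1-yl in place of hydrogen on an aromatic carbon, para to a large group.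

Among the measured compounds shown here, only one measured step bears on this, and it is the same exchange of hydrogen for 4-methylpiperazin-1-yl: a 5.3-fold higher number from compound 1 to compound 2 (0.73 log units; beyond the scatter). That is a modest step, but it lies beyond the usual scatter. The group does not sit on the same carbon in compound 2 and compound 3, and a single step is thin evidence, so the size of the new step remains uncertain. On the strength of a 5.3-fold higher number from compound 1 to compound 2 (0.73 log units; beyond the scatter), a step of similar size in the same direction is expected, namely the estimated 5.0-fold higher number from compound 1 to compound 3 (0.70 log units; beyond the scatter). The expected value for compound 3 is 15000 nM, with an estimated range from 6000 nM to 40000 nM.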

Compound 3, solubility: 1000 nM
The estimate for compound 3 lay 15-fold (1.18 log units) above the measured number; measured number below the stated range.
By their numbers in this assay, from the lowest: compound 3; then compound 1; then compound 2.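

In this assay, putting 4-methylpiperazin-1-yl in place of hydrogen on an aromatic carbon, para to a large group, gives a result in the opposite direction to the same exchange on a different carbon of that ring (a 3.0-fold lower number from compound 1 to compound 3 (0.48 log units; beyond the scatter) against a 5.3-fold higher number from compound 1 to compound 2 (0.73 log units; beyond the scatter)). Both steps are modest but beyond the scatter, so the exchange has no single direction across these three compounds: its sign changes with the carbon that carries the group, and one step could not have shown this. Nothing measured here accounts for the reversal.

The compounds leave open whether this carbon would respond in the same way to a different group, such as a dimethylamino group, a morpholin-4-yl group or a carboxylic acid, and so whether the lower number belongs to 4-methylpiperazin-1-yl or to any substituent placed here. Also open, from the compounds shown here alone, is what the same group would do on the remaining carbons of the ring, since each of the two positions is represented by one compound only.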